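The source may report more compounds than this note shows. Statements on the series, on what has been measured and on what is new or still open speak of the compounds shown alone.

Compound 1 `C=C1C(=O)OC[C@@H]1CCOC(=O)Nc1ccc(F)cc1F` and compound 2 `C=C1C(=O)OC[C@H]1CCOC(=O)Nc1ccccc1F` share one core and differ only in how many fluorines sit on the aromatic ring. In an ADME assay on RAW264.7 cells (Mus musculus) for cytotoxicity, read by MTT assay, with a stated time of 18 h (a higher number here means that more compound is tolerated, a lower number that less compound is tolerated), compound 1 gives 14800 nM, and compound 2 gives 17400 nM; the two numbers lie within the usual scatter of each other, so neither compound can be called better tolerated. Compound 3 `C=C1C(=O)OC[C@@H]1CCOC(=O)Nc1ccccc1F` is the mirror-image partner of compound 2: the two compounds have the same atoms and bonds and differ only in configuration as drawn: 1 of 1 stereo elements differ; a stereocentre at a saturated ring carbon is drawn S in compound 2 and R in compound 3. Among the measured compounds shown here, no measured pair here shows what such a change does. The expected step of a 1.0-fold lower number from compound 2 to compound 3 (0.01 log units; within the scatter) is nothing beyond the scatter. Compound 3 is therefore estimated at 17000 nM, within 8000 nM to 36000 nM.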

Compound 3, half-maximal cytotoxic concentration: 24200 nM
Compound 3: middle estimate off by 1.4-fold (0.15 log units), on the low side; measured number inside the range.
By their numbers in this assay, from the lowest: compounds 1, 2 and 3 (each within the scatter of the next).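

In this assay the stereocentre at a saturated ring carbon now has a measured pair, and swapping it gives a 1.4-fold higher number from compound 2 to compound 3 (0.14 log units; within the scatter) so the drawn configuration has no effect that can be told from the scatter. This comparison isolates that one centre: the fact that compounds 2 and 3 differ only in the configuration as drawn. Hydrogen in place of fluoro on an aromatic carbon, with the configuration as drawn kept, gives a 1.6-fold higher number from compound 1 to compound 3 (0.21 log units; within the scatter) and this also stays within the scatter.

Still open, as far as these compounds go, is whether a chloro or methoxy group on the aromatic ring, or a longer chain linking that ring to the shared core, would give a step beyond the scatter.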